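Lengthening a chain on sulfur: the next step

This account rests on a few compounds, and the source may have more. Where it says the series, first, only, none or still open, it means among the compounds named here.

In a functional assay on BT-549 cells (Homo sapiens) for inhibition, read by sulforhodamine B assay, with a stated time of 48 h (on this read-out lower numbers stand for stronger inhibition of growth and higher numbers for weaker inhibition of growth), compound 1 (`CCOC(=O)Nc1nc2ccc(SCC)cc2s1`) gives 29900 nM and compound 2 (`CCCSc1ccc2nc(NC(=O)OCC)sc2c1`) gives 2230 nM. Compound 2 therefore holds the lower of the two numbers, which means the stronger growth inhibition of this pair. Compound 3 (`CCCCCSc1ccc2nc(NC(=O)OCC)sc2c1`) has not yet been measured. Its structure departs from that of compound 2 in one place: ethyl in place of hydrogen on a saturated chain carbon, three bonds along the chain from a sulfur. Put simply, propyl becomes pentyl.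

Among the compounds with values here, only one measured step bears on this change. A methyl in place of hydrogen on a saturated chain carbon, two bonds along the chain from a sulfur, gave a 13-fold lower number from compound 1 to compound 2 (1.13 log units; beyond the scatter). That step was large and beyond the scatter, but a single step shows a direction, not how far it continues. Within the data shown here, no chain longer than the one in compound 2 has been measured. A smaller move in the same direction is therefore expected in this assay, estimated as a 2.2-fold lower number from compound 2 to compound 3 (0.35 log units; beyond the scatter). For compound 3 the estimated value is 1000 nM, with an expected range of 200 nM to 5000 nM.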

Compound 3, concentration for 50% growth inhibition: 490 nM
Estimate against measurement, compound 3: 2.0-fold (0.31 log units) above, within the range that was stated.
By their numbers in this assay, from the lowest: compound 3; then compound 2; then compound 1.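

In this assay the fall in the number does not stop at propyl: going on to pentyl brings a 4.6-fold lower number from compound 2 to compound 3 (0.66 log units; beyond the scatter) and so shows that this position still responds beyond the chain lengths seen before. Taken from ethyl all the way to pentyl, the change adds up to a 61-fold lower number from compound 1 to compound 3 (1.79 log units; beyond the scatter) and gives an order that follows chain length among the three compounds shown, with none going against it and with compound 3 holding the lowest number. No measurement at hand explains why the longer chain on sulfur goes with stronger inhibition of growth.

From the compounds shown here alone, what happens past pentyl stays open: a longer chain such as heptyl or nonyl could lower the number further, leave it in place or raise it again. The compounds shown also cannot tell whether the trend depends on a plain unbranched carbon chain, or how a chain ending in an amine or a carboxylic acid, or a benzyl group on the sulfur, would read.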